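This account rests on a few compounds, and the source may have more. Where it says the series, first, only, none or still open, it means among the compounds named here.

Measured in a functional assay on A549 cells (Homo sapiens) for cytotoxicity, read by MTT assay, with a stated time of 48 h; a lower number here means a stronger inhibitor, a higher number a weaker inhibitor:
- Compound 1 `COc1ccc(/C=C/c2cc(OC)c(OC)c(OC)c2-c2ccc(OC)cc2)cc1`: 35000 nM
- Compound 2 `COc1cc(/C=C/c2ccccc2)c(-c2ccccc2)c(OC)c1OC`: 79000 nM
- Compound 3 `C=C(c1ccc(OC)cc1)c1cc(OC)c(OC)c(OC)c1-c1ccc(OC)cc1`: 14000 nM

Compound 3 has the lowest number of the three. Compound 4 `C=C(c1ccc(OC)cc1)c1cc(OC)c(OC)c(OC)c1-c1ccc(C(C)(C)C)cc1` differs from it by one change, tert-butyl in place of methoxy on an aromatic carbon. Going by the values given here, the only measured step, a 2.5-fold lower number from compound 1 to compound 3 (0.40 log units; beyond the scatter), leaves the changing ring untouched, so it gives no size for this swap. Compound 2 lacks both outer methoxy groups but differs in other places too, so it offers only weak guidance. Among the compounds with values here, no step clearly beyond the scatter is therefore expected in this assay, and the estimated change is a 1.1-fold higher number from compound 3 to compound 4 (0.06 log units; within the scatter). For compound 4 the expected value is 16000 nM, with an estimated range from 5000 nM to 50000 nM.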

Compound 4, half-maximal inhibitory concentration: 27000 nM
Compound 4: the middle estimate sits 1.7-fold (0.23 log units) below what was measured; measured number inside the range.
By their numbers in this assay, from the lowest: compounds 3, 4 and 1 (each within the scatter of the next, the first and the last beyond it); then compound 2.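

In this assay the swap of 4-methoxyphenyl to 4-(tert-butyl)phenyl gives a 1.9-fold higher number from compound 3 to compound 4 (0.29 log units; within the scatter) and so puts the first measured size on a change at this position. On this pair, a tert-butyl group with more heavy atoms and no hydrogen-bond acceptor takes the place of methoxy without a step beyond the scatter. Nothing available bears on the reason for this result. From the compounds shown here alone, whether an amine or a carboxylic acid at the same position would also stay within the scatter of compound 3 remains open. So does whether the same swap would read alike on the core of compound 1.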